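A few compounds are considered here, and "the series" means these few. Any claim that something is new, unique, unknown or untested is made for them only; others in the source may bear on it.

Compounds measured in a functional assay on the whole organism (strain Wistar) for inhibition, with Rattus norvegicus as the target, read by paw edema, with stated times of 1 h and 3 h, at a dose of 70 mg/kg by the oral route; on this read-out lower numbers stand for less inhibition and higher numbers for more inhibition at the one dose given (going by the name of the read-out):

Compound 1, `c1ccc(C2=NOC(c3c[nH]c4ccccc34)C2CN2CCCCC2)cc1`: 34.3%
Compound 2, `Cc1ccc(C2=NOC(c3c[nH]c4ccccc34)C2CN2CCCCC2)cc1`: 41.2%

Compound 2 has the higher of the two numbers, but its gap to compound 1 is within the scatter, so the two compounds cannot be separated on this read-out. Among the compounds with values here, the one step seen so far, a number 6.9 percentage points higher from compound 1 to compound 2 (within the scatter), came from methyl in place of hydrogen on an aromatic carbon and did not move the read-out beyond the scatter.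

The compound that has not yet been measured is compound 3, `COc1ccc(C2=NOC(c3c[nH]c4ccccc34)C2CN2CCCCC2)cc1`. The difference from compound 2 is methoxy in place of methyl on an aromatic carbon. Within the data shown here, no step of this exact kind, methoxy in place of methyl on an aromatic carbon, has been measured here. Among the measured compounds shown here, the only step that bears on it is the small one at the same position, from compound 1 to compound 2, and that one stayed within the scatter.

On this basis no step beyond the scatter is expected in this assay for compound 3, with the estimated step being a number 0.8 percentage points higher from compound 2 to compound 3 (within the scatter). Compound 3 is therefore estimated at 42%, with an expected range from 28% to 56%.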

Compound 3, a percentage reported as inhibition, in the whole organism at one dose (the size of the read-out at that dose, not a potency): 45.1%
Estimate against measurement, compound 3: 3.1 percentage points below; low and high end bracket the measured number.
By their numbers in this assay, from the lowest: compounds 1, 2 and 3 (each within the scatter of the next, the first and the last beyond it).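

In this assay, methoxy in place of methyl on the aromatic carbon para to a large group gave a number 3.9 percentage points higher from compound 2 to compound 3 (within the scatter), so 4-methylphenyl and 4-methoxyphenyl cannot be separated on this read-out. Within the data shown here, the new information lies in the other comparison: methoxy in place of hydrogen at the same position gave a number 10.8 percentage points higher from compound 1 to compound 3 (beyond the scatter) and is the first modest step in this small set to pass the scatter, showing that a change at this position can move the read-out measurably, although compound 2 remains within the scatter of both neighbours. Nothing available bears on why this step occurs.

The three compounds leave open whether this gain is specific to methoxy or would also appear with a halogen such as chlorine, a hydroxyl, an amine or a longer chain such as ethoxy at this position. With a reading at only one dose, they also leave open how the compounds would compare across a range of doses.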